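This account rests on a few compounds, and the source may have more. Where it says the series, first, only, none or still open, it means among the compounds named here.

Measured compounds and their values:

Compound 1, `COc1cc(/C=N/NC(=O)CCCc2nc3ccccc3c(=O)[nH]2)cc(O)c1O`, gives 80000000 nM in a physicochemical assay, read by spectrophotometry, with a stated time of 15 min; on this read-out higher numbers stand for weaker inhibition and lower numbers for stronger inhibition.
Compound 2, `O=C(CCc1nc2ccccc2c(=O)[nH]1)N/N=C/c1ccc(O)c(O)c1`, gives 105000000 nM in this assay.
Compound 3, `COc1cc(/C=N/NC(=O)CCc2nc3ccccc3c(=O)[nH]2)cc(OC)c1OC`, gives 80000000 nM in this assay.

All three compounds share the same core and differ only in the chain length and in the groups carried on the outer aromatic ring. In this assay compound 1 stands level with compound 3 at the digits shown, and these two are together the lowest of the three numbers, while compound 2 sits nearest the top; none of these gaps reaches beyond the usual scatter, so the three values cannot be told apart with confidence.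

Compound 4, `O=C(CCCc1nc2ccccc2c(=O)[nH]1)N/N=C/c1ccc(O)c(O)c1`, has not yet been measured in this assay. It differs from compound 1 in one place: hydrogen in place of methoxy on an aromatic carbon.

For the measured compounds named here, no step between measured compounds is known, so no direction can be read from the data. The three measured values sit close together whatever groups the outer ring carries, so compound 4 is expected to show no change beyond the scatter, and the step of a 1.1-fold higher number from compound 1 to compound 4 (0.05 log units; within the scatter) is expected to be small. Compound 4 is therefore estimated at 90000000 nM in this assay, within a range of 45000000 nM to 180000000 nM.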

Compound 4, half-maximal inhibitory concentration: 75000000 nM
Estimate against measurement, compound 4: 1.2-fold (0.08 log units) above; the measured number falls inside the stated range.
By their numbers in this assay, from the lowest: compounds 4, 1, 3 and 2 (each within the scatter of the next).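

For the compounds shown here, this pair gives the first reading of a single change: with hydrogen in place of methoxy on an aromatic carbon, ortho to a hydroxy group and meta to a hydroxy group, this assay shows a 1.1-fold lower number from compound 1 to compound 4 (0.03 log units; within the scatter). The earlier compounds shown here differed in more than one place, so they could not isolate this position, whereas here everything else in the structure stays the same. On this evidence, methoxy and hydrogen at this position cannot be told apart in this measurement, and nothing shown offers an explanation for that.

As far as these compounds go, this single pair cannot show whether the result is specific to these two groups, so it remains open whether an amine, a carboxylic acid or a chlorine atom on the same aromatic carbon would give a value distinct from those of compound 1 and compound 4. It also leaves open whether the same swap would read alike on a compound with a longer chain, or with the neighbouring hydroxy groups replaced.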